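Cyclohexyl to phenyl on the ring nitrogen: compound 4

The source may hold more compounds than are shown below. What is called first, only, known or untested is meant among the compounds shown, and "the series" means these compounds.

For the measured compounds named here, in an ADME assay on Huh-7 cells (Homo sapiens) for cytotoxicity (a higher number here means a weaker inhibitor, a lower number a stronger inhibitor), compound 1 `CN(c1cc2ncc(=O)[nH]c2cc1Nc1nc(-c2ccccc2)cs1)C1CCCCC1` gives 62500 nM, the second highest of the three numbers measured so far. Compound 2 `CN(c1cc2ncc(=O)[nH]c2cc1Nc1nc(-c2ccc(-c3ccccc3)cc2)cs1)C1CCCCC1` gives 82000 nM, and compound 3 `CC(C)Cc1nc2cc(N(C)C3CCCCC3)c(Nc3nc(-c4ccccc4)cs3)cc2[nH]c1=O` gives 33300 nM. Neither neighbour separates from compound 1 beyond the scatter: a 1.3-fold higher number from compound 1 to compound 2 (0.12 log units; within the scatter) and a 1.9-fold lower number from compound 1 to compound 3 (0.27 log units; within the scatter).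

Compound 4 `CN(c1ccccc1)c1cc2ncc(=O)[nH]c2cc1Nc1nc(-c2ccccc2)cs1` differs from compound 1 in one place: phenyl in place of cyclohexyl on a nitrogen on an aromatic ring. Going by the values given here, both measured steps alter an aromatic carbon and leave the nitrogen untouched, so no step bears directly on this change; both also stayed within the scatter, and the series so far shows no move beyond it in this assay. For compound 4 the expectation is therefore no step beyond the scatter, an estimated 60000 nM with a range of 25000 nM to 150000 nM. The expected step from compound 1 is a 1.0-fold lower number from compound 1 to compound 4 (0.02 log units; within the scatter).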

Compound 4, half-maximal inhibitory concentration: 15900 nM
The estimate for compound 4 lay 3.8-fold (0.58 log units) above the measured number, and the stated range ends above it.
By their numbers in this assay, from the lowest: compound 4; then compounds 3, 1 and 2 (each within the scatter of the next, the first and the last beyond it).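

In this assay, for the compounds shown here, the group on the nitrogen is the first place to give a step beyond the scatter, with a 3.9-fold lower number from compound 1 to compound 4 (0.59 log units; beyond the scatter) on exchanging cyclohexyl for phenyl. The heavy-atom count stays the same and the entering ring is aromatic rather than non-aromatic, whereas the changes on aromatic carbon in compound 2 and compound 3 stayed within the scatter. Nothing available here accounts for the step.

As far as these compounds go, whether a pyridyl ring, a phenyl carrying methoxy or an open chain such as isopropyl on this nitrogen would follow phenyl or cyclohexyl remains open. So does the outcome of pairing phenyl here with the isobutyl of compound 3.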